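The source may hold more compounds than are shown below. What is called first, only, known or untested is meant among the compounds shown, and "the series" means these compounds.

The measured compounds:
compound 1, `CC1(C)C[C@@H](CN([C@H](CCC(F)(F)F)C(N)=O)S(=O)(=O)c2ccc(Cl)cc2)O1`, 14.9 10^-6 cm/s
compound 2, `NC(=O)[C@@H](CCC(F)(F)F)N(C[C@H]1CCCOC1)S(=O)(=O)c1ccc(Cl)cc1`, 18.2 10^-6 cm/s
compound 3, `NC(=O)[C@@H](CCC(F)(F)F)N(C[C@@H]1CCCOC1)S(=O)(=O)c1ccc(Cl)cc1`, 18.4 10^-6 cm/s

All three numbers come from an ADME assay on MDCKII-LE cells (Canis lupus familiaris) for permeability, read by transwell migration, in the apical to basolateral direction; a higher number here means that the compound crosses the layer faster, a lower number that the compound crosses the layer more slowly. Compound 3 stands apart from neither of the other two: a 1.0-fold higher number from compound 2 to compound 3 (0.00 log units; within the scatter), which fits (the fact that compounds 2 and 3 differ only in the configuration as drawn), and a 1.2-fold higher number from compound 1 to compound 3 (0.09 log units; within the scatter). Compound 4, `NC(=O)[C@@H](CCC(F)(F)F)N(C[C@H]1CCCO1)S(=O)(=O)c1ccc(Cl)cc1`, has not yet been measured in this assay. It differs from compound 3 in one place: oxolan-2-yl in place of oxan-3-yl on a saturated chain carbon bound to a sulfonamide nitrogen. The measured steps that bear on this change are the two earlier swaps of the group at the same place, and both stayed within the scatter: a 1.2-fold higher number from compound 1 to compound 2 (0.09 log units; within the scatter); a 1.2-fold higher number from compound 1 to compound 3 (0.09 log units; within the scatter). Across the three measured compounds the group at this position has so far made no difference that rises above the noise of this assay. Compound 4 is therefore expected to show no step beyond the scatter, a 1.1-fold lower number from compound 3 to compound 4 (0.03 log units; within the scatter). Compound 4 is estimated at 17 10^-6 cm/s, with a range from 10 10^-6 cm/s to 28 10^-6 cm/s.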

Compound 4, apparent permeability: 19.1 10^-6 cm/s
Compound 4: the middle estimate sits 1.1-fold (0.05 log units) below what was measured; the measured number falls inside the stated range.
By their numbers in this assay, from the lowest: compounds 1, 2, 3 and 4 (each within the scatter of the next).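

The step from a six-membered to a five-membered non-aromatic ring, oxolan-2-yl in place of oxan-3-yl on a saturated chain carbon bound to a sulfonamide nitrogen, leaves this assay unmoved beyond the scatter: a 1.0-fold higher number from compound 3 to compound 4 (0.02 log units; within the scatter) and a 1.0-fold higher number from compound 2 to compound 4 (0.02 log units; within the scatter). Measured against the 4,4-dimethyloxetan-2-yl group, the new ring gives a 1.3-fold higher number from compound 1 to compound 4 (0.11 log units; within the scatter), so a third ring size at this place also stays within the scatter, and no group shown here separates from the others. Nothing on hand bears on why this ring change leaves the number where it is.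

Every group shown at this place is a saturated ring holding one oxygen and no net charge. The compounds leave open whether an amine, a carboxylic acid or an open ether chain there would produce a step beyond the scatter.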